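This account rests on a few compounds, and the source may have more. Where it says the series, first, only, none or still open, it means among the compounds named here.

Compound 1 `CS(=O)(=O)NC1CCC(CN2CCN(c3cc(=O)c4cc(C(F)(F)F)cc([N+](=O)[O-])c4s3)CC2)CC1` sits at the top of the three numbers in hand: in an ADME assay on cells (Hepatocyte, Mus musculus) for metabolic stability, with a stated time of 30 min (a higher number here means that more of the compound is left, a lower number that less of the compound is left), compound 1 gives 111%. Compound 3 `O=c1cc(N2CCN(CC3CCCCC3)CC2)sc2c([N+](=O)[O-])cc(C(F)(F)F)cc12` comes nearest, and in this assay compound 3 gives 80.6%, so that the step of a number 30.4 percentage points lower from compound 1 to compound 3 (beyond the scatter). Compound 2 `O=C(OC1CCC(CN2CCN(c3cc(=O)c4cc(C(F)(F)F)cc([N+](=O)[O-])c4s3)CC2)CC1)c1ccncc1` lies furthest off; in this assay compound 2 gives 1.4%, and the step of a number 109.6 percentage points lower from compound 1 to compound 2 (beyond the scatter). Between those two, a number 79.2 percentage points higher from compound 2 to compound 3 (beyond the scatter).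

Compound 4 `O=c1cc(N2CCN(CC3CCC(O)CC3)CC2)sc2c([N+](=O)[O-])cc(C(F)(F)F)cc12` differs from compound 1 in one place: hydroxy in place of methanesulfonamido on a saturated ring carbon.

The two steps that bear on this change both start from compound 1 and both point downward: a number 30.4 percentage points lower from compound 1 to compound 3 (beyond the scatter) when the group is simply taken away, and a number 109.6 percentage points lower from compound 1 to compound 2 (beyond the scatter) when a larger group is put in. A hydroxy group is a smaller change than either, so a drop beyond the scatter is expected, but a modest one, nearer to what compound 3 shows than to compound 2. Compound 4 is therefore estimated at 85%, in a range from 55% to 105%, which means an expected step of a number 26 percentage points lower from compound 1 to compound 4 (beyond the scatter).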

Compound 4, percent of the compound remaining: 51.2%
Compound 4: middle estimate off by 33.8 percentage points, on the high side, outside the stated range (below it).
By their numbers in this assay, from the lowest: compound 2; then compound 4; then compound 3; then compound 1.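

A free hydroxy on this saturated ring carbon is not a neutral change in this assay: it lies below the bare ring, with a number 29.4 percentage points lower from compound 3 to compound 4 (beyond the scatter), and further below the methanesulfonamido group, with a number 59.8 percentage points lower from compound 1 to compound 4 (beyond the scatter), so that at this position the methanesulfonamido group, hydrogen and hydroxy fall in three separate places. The same oxygen carrying (pyridin-4-yl)carbonyl gives the lowest number of the set, and removing that acyl group accounts for only part of the gap to compound 1, with a number 49.8 percentage points higher from compound 2 to compound 4 (beyond the scatter). Nothing at hand explains these differences.

The compounds shown leave open whether a methoxy group or an amine on the same ring carbon would fall near compound 4 or nearer compound 3. They also leave open whether an acetamido group would hold the number of compound 1.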